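Swapping the basic amine on a shared oxime carbamate core

A few compounds are considered here, and "the series" means these few. Any claim that something is new, unique, unknown or untested is made for them only; others in the source may bear on it.

Compound 1 `O=C(Nc1cccc(Cl)c1)O/N=C(\C1CCCCC1)C(Cn1ccnc1)C1CCCCC1` — 10.8 nM; 8.78 nM; 1000 nM (3 entries)
Compound 2 `O=C(Nc1ccccc1)O/N=C(\C1CCCCC1)C(CN1CCN(c2ccccc2)CC1)C1CCCCC1` — > 1000 nM

In an assay on isolated protein for displacement of a labelled ligand from metabotropic glutamate receptor 5 (Rattus norvegicus) (on this read-out higher numbers stand for weaker inhibition and lower numbers for stronger inhibition), compound 1 gives 10.8 nM; 8.78 nM; 1000 nM (3 entries). From the compounds shown here alone, for compound 2 only a limit is reported, > 1000 nM, so its true value is unknown (the limit of > 1000 nM in this assay, at which 1 of the 2 values shown sits). Compound 3 `O=C(Nc1ccccc1)O/N=C(\C1CCCCC1)C(CN1CCc2ccccc2C1)C1CCCCC1` differs from compound 2 by 1,2,3,4-tetrahydroisoquinolin-2-yl in place of 4-phenylpiperazin-1-yl on a saturated chain carbon, two bonds along the chain from a carbon with a double bond to nitrogen and a saturated ring carbon. Among the measured compounds shown here, no measured pair carries this change, so the estimated step is a step that the limit leaves unreadable from compound 2 to compound 3, nothing expected beyond the usual scatter. Compound 3 is therefore expected to sit near the same weak end, at about 2000 nM, with a likely range from 300 nM to 10000 nM.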

Compound 3, inhibition constant: > 1000 nM
Compound 3 was reported as a limit (the forecaster's own chance of this, stated with the estimate: 60%); the middle value does not contradict the limit.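

Compound 2 and compound 3 are both reported only as limits, and no step can be read between them. From the compounds shown here alone, what stays open is where either compound's true value lies in this assay, and whether 1,2,3,4-tetrahydroisoquinolin-2-yl and 4-phenylpiperazin-1-yl differ at all.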